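Swapping the aryl group on the amide carbonyl

This account rests on a few compounds, and the source may have more. Where it says the series, first, only, none or still open, it means among the compounds named here.

Measured compounds:
Compound 1 `O=C(NCc1ccc(CNS(=O)(=O)c2ccccc2)cc1)c1ccccc1Cl` in an assay on MDA-MB-231 cells for binding affinity to C-X-C chemokine receptor type 4 (Homo sapiens), read by immunofluorescence and microscopy, with stated times of 10 min and 30 min (on this read-out lower numbers stand for an effect already at smaller amounts and higher numbers for an effect only at larger amounts of compound), gives 10 nM.
Compound 2 `Cc1ccc(S(=O)(=O)NCc2ccc(CNC(=O)c3ccc(F)cc3)cc2)cc1` gives 1 nM.
Compound 3 `Cc1ccc(S(=O)(=O)NCc2ccc(CNC(=O)c3cccc(C)c3)cc2)cc1` gives 1000 nM.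

Compound 3 gives the highest number of the three; compound 1 stands nearest to it, compound 2 furthest, and both gaps lie beyond the scatter. Within the data shown here, the single measured step that touches the aryl group on the carbonyl, a 1000-fold higher number from compound 2 to compound 3 (3.00 log units; beyond the scatter), shows that this position alone can move the read-out a long way.

Compound 4 `Cc1ccc(S(=O)(=O)NCc2ccc(CNC(=O)c3ccccc3Cl)cc2)cc1` is compound 3 with 2-chlorophenyl in place of 3-methylphenyl on a carbonyl carbon. This exact exchange has not been measured, but compound 1 already carries 2-chlorophenyl on its carbonyl and gives a low number, while differing from compound 4 only in the group on the sulfonyl side. Compound 4 is therefore expected to show a large drop, a 100-fold lower number from compound 3 to compound 4 (2.00 log units; beyond the scatter), landing close to compound 1. The estimate for compound 4 is 10 nM, with a range from 2 nM to 60 nM.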

Compound 4, effective concentration (reported as EC, without a stated level of effect): 10 nM
Compound 4: middle estimate and measured number agree at the digits printed, and the stated range covers the measured number.
By their numbers in this assay, from the lowest: compound 2; then compounds 1 and 4 (each within the scatter of the next); then compound 3.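

With 2-chlorophenyl in place of 3-methylphenyl on the carbonyl carbon, this assay shows a 100-fold lower number from compound 3 to compound 4 (2.00 log units; beyond the scatter) and so the high number of compound 3 does not extend to every substituted phenyl group at this position. The 2-chlorophenyl group does not match the 4-fluorophenyl group here, since the exchange between them gives a 10-fold higher number from compound 2 to compound 4 (1.00 log units; beyond the scatter) and the choice of group on the carbonyl still matters among the lower numbers. Methyl in place of hydrogen on an aromatic carbon gives no change at the digits printed from compound 1 to compound 4 (within the scatter) and so, with 2-chlorophenyl on the carbonyl, this second change leaves the read-out in place. From the compounds shown here alone, how a phenyl group carrying an amine or a carboxylic acid would behave on the carbonyl carbon remains open. Nothing measured here explains why these groups give such different numbers.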